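The source may report more compounds than this note shows. Statements on the series, on what has been measured and on what is new or still open speak of the compounds shown alone.

Compound 1 `COc1ccc(-c2cnc(NC(=O)CCc3ccccc3)n2C)cc1`: > 100000 nM
Compound 2 `Cn1c(-c2ccc([N+](=O)[O-])cc2)cnc1NC(=O)c1ccc(F)cc1`: > 50000 nM

In a toxicity assay on THP-1 cells (Homo sapiens) for inhibition (a higher number here means that more compound is tolerated, a lower number that less compound is tolerated), compound 1 gives > 100000 nM; this is a limit of the measurement, not a number, as the limit of > 100000 nM in this assay, at which 1 of the 2 values shown sits, makes plain. Compound 2 gives > 50000 nM in this assay, again only a limit. Both compounds share the same core and both are tolerated up to the ceiling tested. Compound 3 `COc1ccc(-c2cnc(NC(=O)c3cccc(Cl)c3)n2C)cc1` is not yet measured; it differs from compound 1 in one place: 3-chlorophenyl in place of phenethyl on a carbonyl carbon. For the measured compounds named here, no measured step between compounds of this set exists, so no size of step can be drawn from data. Compound 3 is expected to stay close to compound 1, with a step of a number no higher from compound 1 to compound 3 (the limit leaves the size open) in this assay that lies within the usual scatter. The estimate for compound 3 in this assay is 100000 nM, expected between 30000 nM and 300000 nM.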

Compound 3, half-maximal cytotoxic concentration: > 28000 nM
Compound 3 was reported as a limit; the forecaster's own chance of this, stated with the estimate: 70%; the middle value does not contradict the limit.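

The step from compound 1 to compound 3 cannot be read, since both results are limits of the measurement and not numbers. The compounds shown leave open what half-maximal cytotoxic concentration any of them has in this assay.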